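The source may report more compounds than this note shows. Statements on the series, on what has been measured and on what is new or still open speak of the compounds shown alone.

Measured so far in an ADME assay on Huh-5-2 cells (Homo sapiens) for cytotoxicity, read by WST assay, with a stated time of 3 days; a lower number here means that less compound is tolerated, a higher number that more compound is tolerated: compound 1, `O=c1c(OCc2ccccc2[N+](=O)[O-])c(-c2ccccc2)oc2cc(O)cc(O)c12`, gives 51000 nM; compound 2, `Cc1ccccc1COc1c(-c2ccccc2)oc2cc(O)cc(O)c2c1=O`, gives 55000 nM; compound 3, `O=c1c(OCc2ccc([N+](=O)[O-])cc2)c(-c2ccccc2)oc2cc(O)cc(O)c12`, gives 40000 nM.

Compound 4, `Cc1ccc(COc2c(-c3ccccc3)oc3cc(O)cc(O)c3c2=O)cc1`, has not yet been measured. It differs from compound 3 by methyl in place of nitro on an aromatic carbon. The same change is made from compound 1 to compound 2, where it reads methyl in place of nitro on an aromatic carbon and gave a 1.1-fold higher number from compound 1 to compound 2 (0.03 log units; within the scatter). The two places are not the same word for word: in compound 1 the group sits ortho to a large group, in compound 3 para to a large group, so this is the same kind of change rather than the same one. The cores of compound 1 and compound 3 differ by 4-nitrophenyl in place of 2-nitrophenyl on a saturated chain carbon bound to an oxygen on an aromatic ring, with a 1.3-fold lower number from compound 1 to compound 3 (0.11 log units; within the scatter).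

Because the earlier instance gave a 1.1-fold higher number from compound 1 to compound 2 (0.03 log units; within the scatter), the expected step here is a 1.1-fold higher number from compound 3 to compound 4 (0.05 log units; within the scatter). In this assay compound 4 is estimated at 45000 nM, between 25000 nM and 80000 nM.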

Compound 4, half-maximal cytotoxic concentration: 40000 nM
Compound 4: middle estimate off by 1.1-fold (0.05 log units), on the high side, within the range that was stated.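

In this assay, methyl in place of nitro gives no change at the digits printed from compound 3 to compound 4 (within the scatter) and reads the same on both cores: the same change on two cores in this assay, a 1.1-fold higher number (0.03 log units; within the scatter) from compound 1 to compound 2 and no change at the digits printed (within the scatter) from compound 3 to compound 4, 1.1-fold (0.03 log units) apart, within the scatter of two such steps. The other two steps, a 1.4-fold lower number from compound 2 to compound 4 (0.14 log units; within the scatter) and a 1.3-fold lower number from compound 1 to compound 4 (0.11 log units; within the scatter), also lie within the scatter. The change therefore carries across these two cores without a readable step, but this does not show that it would carry to a different core, and as neither instance gives a step beyond the scatter, it says nothing about how a real effect of this change would transfer.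

The compounds shown leave open whether an amine, a carboxylic acid or a longer chain on the same aromatic carbon would also stay within the scatter of these values.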